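Cyanoacrylate in place of the thioether amide side chain

The source may report more compounds than this note shows. Statements on the series, on what has been measured and on what is new or still open speak of the compounds shown alone.

Compound 1 `CNC(=N)Nc1nc(-c2ccc(OC)cc2)c(-c2ccc(OC)cc2)s1` gives 62 nM in a functional assay with Oryctolagus cuniculus as the target; on this read-out higher numbers stand for weaker inhibition and lower numbers for stronger inhibition. Compound 2 `C/N=C(/NC)Nc1nc(-c2ccc(OC)cc2)c(-c2ccc(OC)cc2)s1` gives 970 nM in this assay, which is a 16-fold higher number from compound 1 to compound 2 (1.19 log units; beyond the scatter). Compound 3 `COc1ccc(-c2nc(CNC(=O)CSC)sc2-c2ccc(OC)cc2)cc1` is reported in this assay only as a limit, < 100 nM, not as a number. It thus sits at the limit of < 100 nM in this assay, at which 1 of the 3 values shown sits. The measured steps onto that aromatic carbon are an at least 9.7-fold lower number from compound 2 to compound 3 (0.98 log units; beyond the scatter) and a step that the limit leaves unreadable from compound 1 to compound 3. Compound 4 `CCOC(=O)/C(C#N)=C/c1nc(-c2ccc(OC)cc2)c(-c2ccc(OC)cc2)s1` differs from compound 3 by 2-cyano-2-(ethoxycarbonyl)ethenyl in place of ((((methylsulfanyl)methyl)carbonyl)amino)methyl on an aromatic carbon. For the measured compounds named here, both measured steps onto this carbon start from other groups, and the limit for compound 3 leaves its own value open, so no step gives the size of this change. Compound 4 is expected near 200 nM, between 40 nM and 1000 nM, an estimated at least 2.0-fold higher number from compound 3 to compound 4 (0.30 log units; that floor lies within the scatter).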

Compound 4, half-maximal inhibitory concentration: < 10 nM
Compound 4: a limit, no number; the forecaster's own chance of this, stated with the estimate: 25%; at least 20-fold (1.30 log units) between middle value and limit.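

In this assay compound 4 is reported only as a limit, < 10 nM. This aromatic carbon therefore accepts 2-cyano-2-(ethoxycarbonyl)ethenyl, a side chain with 0 hydrogen-bond donors, with stronger inhibition than the earlier measured compounds: an at least 97-fold lower number from compound 2 to compound 4 (1.98 log units; beyond the scatter) and an at least 6.2-fold lower number from compound 1 to compound 4 (0.79 log units; beyond the scatter). The step from compound 3 cannot be read, as both values are limits.

From the compounds shown here alone, the true value of compound 4 stays open, and so does the share of the nitrile and the ethoxycarbonyl part in this result. A carboxylic acid in place of the ethyl ester would test the latter.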